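A few compounds are considered here, and "the series" means these few. Any claim that something is new, unique, unknown or untested is made for them only; others in the source may bear on it.

In a functional assay on RS4-11 cells (Homo sapiens) for inhibition, read by CCK-8 assay, with a stated time of 48 h, tested at 20 uM (a higher number here means more inhibition of growth at the concentration tested, a lower number less inhibition of growth), compound 1 `COc1ccc(Cc2nnc(NC(=O)/C(C#N)=C/c3ccccc3OS(=O)(=O)c3ccc(C)cc3)s2)cc1` gives 70% and does not stand apart from its two measured relatives. Compound 2 `COc1ccc(Cc2nnc(NC(=O)/C(C#N)=C/c3ccccc3OS(=O)(=O)c3ccc(OC)cc3)s2)cc1` gives 78% in the same test, and compound 3 `COc1ccc(Cc2nnc(NC(=O)/C(C#N)=C/c3ccccc3OS(=O)(=O)c3ccc(F)cc3)s2)cc1` gives 80% there, so all three numbers lie within the scatter of one another. These compounds differ only in one group on an aromatic carbon, and each exchange has been small: a number 8 percentage points higher from compound 1 to compound 2 (within the scatter), a number 10 percentage points higher from compound 1 to compound 3 (within the scatter), and a number 2 percentage points higher from compound 2 to compound 3 (within the scatter) as well.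

Compound 4 `Cc1ccc(S(=O)(=O)Oc2ccccc2/C=C(\C#N)C(=O)Nc2nnc(Cc3ccc(F)cc3)s2)cc1` keeps the methyl group of compound 1 and changes a different group: fluoro in place of methoxy on an aromatic carbon, which turns 4-methoxybenzyl into 4-fluorobenzyl. Among the compounds with values here, the nearest precedent is the exchange from compound 2 to compound 3, also fluoro in place of methoxy on an aromatic carbon, but it was made at another place in the molecule and so bears on this change only indirectly. Within the data shown here, no measured compound varies the 4-methoxybenzyl group itself. On these data alone, with every measured step inside the scatter, no step beyond the scatter is expected here, and the direction remains open. The expected change is a number 4 percentage points higher from compound 1 to compound 4 (within the scatter) and would remain a small one. Compound 4 is estimated at 74%, with an expected range from 60% to 86%.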

Compound 4, percent growth inhibition at one concentration: 72%
Compound 4: the middle estimate sits 2 percentage points above what was measured; low and high end bracket the measured number.
By their numbers in this assay, from the lowest: compounds 1, 4, 2 and 3 (each within the scatter of the next).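

Within the data shown here, the step from methoxy to fluoro at the benzyl group gives the first direct reading at this position, on an aromatic carbon para to a large group: in this assay, the exchange of 4-methoxybenzyl for 4-fluorobenzyl gives a number 2 percentage points higher from compound 1 to compound 4 (within the scatter). The earlier compounds shown here varied only a group at another place in the molecule, so they could bear on this position only indirectly. The exchange now reads alike at both places, and the two steps cannot be told apart: the same change on two cores in this assay, a number 2 percentage points higher (within the scatter) from compound 2 to compound 3 and a number 2 percentage points higher (within the scatter) from compound 1 to compound 4, 0 percentage points apart, within the scatter of two such steps. Across these two pairs, then, fluoro and methoxy are interchangeable within the scatter of this single-concentration test, at either place and on either partner group, and no compound shown goes against that reading.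

What the compounds leave open is whether this position stays as undemanding with a group of another kind, such as an amine, a carboxylic acid or a longer chain like butoxy, in place of fluoro or methoxy. Also open, on these data alone, is whether compounds that cannot be separated in this assay would separate at lower concentrations.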